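Chloro for Methyl on Two Related Cores

The compounds below may be only part of what the source reports. "The series", "measured", "known", "first", "only" and "open" are said of these compounds alone.

Measured so far:
- compound 1, `COc1ccccc1N1CCN(CC2=NS(=O)(=O)c3ccc(C)cc3N2)CC1`: < 5 (a limit)
- compound 2, `COc1ccccc1N1CCN(CC2=NS(=O)(=O)c3ccc(Cl)cc3N2)CC1`: 5.28
- compound 3, `COc1ccccc1N1CCN(CC2Nc3cc(C)ccc3S(=O)(=O)N2)CC1`: 6

In a functional assay on Vas deferens for antagonist activity at Alpha-1A adrenergic receptor (Rattus norvegicus) (on this read-out lower numbers stand for lower potency and higher numbers for higher potency (the scale is a negative logarithm)), compound 1 reaches only a limit, < 5. Compound 2 gives 5.28, and compound 3 gives 6, the highest of the two numbers. The change chloro in place of methyl on an aromatic carbon produced a number at least 0.28 log units higher from compound 1 to compound 2 (that floor lies within the scatter), a floor that rests on (the limit of < 5 in this assay, at which 1 of the 3 values shown sits). Compound 4, `COc1ccccc1N1CCN(CC2Nc3cc(Cl)ccc3S(=O)(=O)N2)CC1`, not yet measured, carries the same change on the core of compound 3: chloro in place of methyl on an aromatic carbon. The difference between the two cores is not broken down here. Because the earlier step was a number at least 0.28 log units higher from compound 1 to compound 2 (that floor lies within the scatter) and compound 3 already stands at 6, the expected step is a number 0.30 log units higher from compound 3 to compound 4 (within the scatter). Compound 4 is therefore estimated at 6.3, between 5.6 and 7.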

Compound 4, negative logarithm of the antagonist equilibrium constant: 5.05
The estimate for compound 4 lay 1.25 log units above the measured number, and the stated range ends above it.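

Putting chloro in place of methyl on the core of compound 3 gave a number 0.95 log units lower from compound 3 to compound 4 (beyond the scatter) in this assay. Set side by side, the same change does not give the same result on the two cores: the same change on two cores in this assay, a number at least 0.28 log units higher (that floor lies within the scatter) from compound 1 to compound 2 and a number 0.95 log units lower (beyond the scatter) from compound 3 to compound 4, at least 1.23 log units apart, beyond the scatter of two such steps Two pairs give no reason for this difference and no rule for any other core, and the earlier step is only a floor resting on a limit: the limit of < 5 in this assay, at which 1 of the 4 values shown sits.

The compounds shown leave open what a fluoro, a methoxy or an amine at this place would do on either core. They also leave open whether a longer chain, such as ethyl, would follow methyl or chloro.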